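This account rests on a few compounds, and the source may have more. Where it says the series, first, only, none or still open, it means among the compounds named here.

Measured compounds:
compound 1 `COc1cc(CC(O)c2ccc(-c3ccc(C=O)cc3)cc2)c([N+](=O)[O-])cc1OC` — an ADME assay on HeLa Rh cells (Homo sapiens) for cytotoxicity, read by microscopy; a lower number here means that less compound is tolerated, a higher number that more compound is tolerated: > 245000 nM
compound 2 `COc1cc(CC(O)c2ccc(-c3cccc(C#N)c3)cc2)c([N+](=O)[O-])cc1OC` — this assay: 5200 nM

In this assay compound 1 reaches only a limit, (the limit of > 245000 nM in this assay, at which 1 of the 2 values shown sits), and not a number. For the measured compounds named here, compound 2 therefore holds the only number among the values shown. Going by the values given here, the one measured step, an at least 47-fold lower number from compound 1 to compound 2 (1.67 log units; beyond the scatter), is large and beyond the scatter, so a change on the distal phenyl ring has already moved the read-out a long way once.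

Compound 3 `COc1cc(CC(O)c2ccc(-c3ccccc3[N+](=O)[O-])cc2)c([N+](=O)[O-])cc1OC` carries 2-nitrophenyl in place of 3-cyanophenyl on an aromatic carbon. Among the compounds with values here, no measured step describes this exchange; the step from compound 1 to compound 2 shows only that such a substituent swap can shift the number strongly, without telling the direction for a nitro group. The estimate for compound 3 is accordingly wide, with a 3.8-fold higher number from compound 2 to compound 3 (0.59 log units; beyond the scatter) expected toward a somewhat higher number. Compound 3 is expected to give about 20000 nM, within 3000 nM to 245000 nM.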

Compound 3, half-maximal cytotoxic concentration: 9500 nM
The estimate for compound 3 lay 2.1-fold (0.32 log units) above the measured number; the measured number falls inside the stated range.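

Replacing the 3-cyanophenyl group with 2-nitrophenyl gives a 1.8-fold higher number from compound 2 to compound 3 (0.26 log units; within the scatter), so in this assay these two groups, which carry different substituents, cannot be told apart at this position. Set against 4-formylphenyl, the 2-nitrophenyl group gives an at least 25-fold lower number from compound 1 to compound 3 (1.41 log units; beyond the scatter), so a large step in the same direction now appears with a second group and no longer rests on the nitrile alone. Compound 1 remains the one compound of the three that is set apart, and its value is only a limit: the limit of > 245000 nM in this assay, at which 1 of the 3 values shown sits.

The compounds shown leave open whether the formyl group itself or its place on the ring sets compound 1 apart. They also leave open how an amine or a carboxylic acid on this ring would read in this assay.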